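The source may hold more compounds than are shown below. What is called first, only, known or untested is meant among the compounds shown, and "the series" means these compounds.

Measured compounds:
- compound 1, `O=C(Cc1cccnc1)c1cc2cc(Cl)ccc2[nH]1`: 24%
- compound 2, `OC(Cc1cccnc1)c1cc2ccccc2[nH]1`: "not active" (no number reported)
- compound 3, `O=C(Nc1cccnc1)c1cc2ccccc2[nH]1`: "not active" (no number reported)

Of the compounds shown here, three sharing the same core have been tested in an in vitro assay on P815B cells for inhibition of Indoleamine 2,3-dioxygenase 1 (Mus musculus), tested at 20 uM; on this read-out lower numbers stand for less inhibition and higher numbers for more inhibition at the one concentration tested (going by the name of the read-out). Going by the values given here, compound 1 `O=C(Cc1cccnc1)c1cc2cc(Cl)ccc2[nH]1` is the only one for which a number is given: in this assay compound 1 shows 24%. Compound 2 `OC(Cc1cccnc1)c1cc2ccccc2[nH]1` is reported as "not active" (no number reported), and compound 3 `O=C(Nc1cccnc1)c1cc2ccccc2[nH]1` likewise as "not active" (no number reported), so neither carries a figure that could be set against compound 1. Among the numbers shown, compound 1 therefore stands alone, and nothing in this set tells how the core responds to a change on its six-membered carbon ring.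

Compound 4 `Cc1ccc2[nH]c(C(=O)Cc3cccnc3)cc2c1` has not yet been measured. It differs from compound 1 in one place: methyl in place of chloro on an aromatic carbon. Among the compounds with values here, because the only comparison available is the single value 24% of compound 1, there is no step between measured compounds on which to build. The exchange of one halogen for one carbon at the same aromatic position is expected to move this assay by no more than the scatter of repeated runs, with a slight lean toward less inhibition. Compound 4 is expected to give 18%, within a range from 5% to 33%, which corresponds to an expected step of a number 6 percentage points lower from compound 1 to compound 4 (within the scatter).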

Compound 4, a percentage reported as inhibition, at one concentration (the size of the read-out at that concentration, not a potency): 21%
Compound 4: the middle estimate sits 3 percentage points below what was measured; the measured number falls inside the stated range.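

In this assay, going by these compounds alone, the exchange of chloro for methyl on an aromatic carbon of the six-membered aromatic ring of carbon only comes with a number 3 percentage points lower from compound 1 to compound 4 (within the scatter) and gives the first step that can be read at any position of the shared core. At this position, chloro and methyl, each a single heavy atom with no hydrogen-bond donors or acceptors, cannot be told apart, and the inhibition seen with compound 1 is therefore not unique to the chloro group. Nothing measured here accounts for this result.

The steps to compound 2 and compound 3 cannot be read, as both are reported without a number, so the contribution of the carbonyl and the chain bearing the pyridine-like ring remains unsettled. On these data alone, it also remains open whether a hydrogen, an amine, a carboxylic acid or a longer chain on the same aromatic carbon would stay within the scatter of compound 1 and compound 4 or move this assay beyond it.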